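The compounds below may be only part of what the source reports. "The series", "measured", "known", "first", "only" and "open" are said of these compounds alone.

Measured so far in an ADME assay on C8166 cells (Homo sapiens) for cytotoxicity; on this read-out higher numbers stand for lower toxicity in this test and lower numbers for higher toxicity in this test:
- compound 1 `CCN1C(=O)N(c2ccccc2)C(=O)N(c2ccccc2)c2cc(C(F)(F)F)ccc21`: > 4000 nM
- compound 2 `CCN1C(=O)N(c2ccc(OC)cc2)C(=O)N(c2ccccc2)c2cc(C(F)(F)F)ccc21`: > 16000 nM
- compound 3 `CCN1C(=O)N(c2cccc(C(=O)NC)c2)C(=O)N(c2ccccc2)c2cc(C(F)(F)F)ccc21`: > 22000 nM

Compound 2 stands at > 16000 nM, which is a limit of the assay and not a number. The two other entries are limits as well, so no order can be read among the three compounds.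

Compound 4 `CCN1C(=O)N(c2ccc(O)c(C)c2)C(=O)N(c2ccccc2)c2cc(C(F)(F)F)ccc21` has not yet been measured. It has the same atoms as compound 2, joined differently: 4-hydroxy-3-methylphenyl takes the place of 4-methoxyphenyl on an amide-type nitrogen in a ring (4-hydroxy-3-methylphenyl in place of 4-methoxyphenyl on an amide-type nitrogen in a ring).

For the measured compounds named here, two measured steps bear on this change, since both alter the aromatic group on that same nitrogen. Going by the values given here, the first is a step that the two limits leave unreadable from compound 1 to compound 2, and the second is a step that the two limits leave unreadable from compound 2 to compound 3. Neither has a size that can be read, so they offer no direction for compound 4. With so little to go on, no step beyond the usual scatter is expected in this assay, and this expectation is a weak one. Compound 4 may also turn out to be reported only as a limit.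

The expected size of the change is a step that the limit leaves unreadable from compound 2 to compound 4. The estimate for compound 4 is 20000 nM, with an expected range from 7000 nM to 60000 nM.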

Compound 4, half-maximal cytotoxic concentration: 17000 nM
Compound 4: the middle estimate sits 1.2-fold (0.07 log units) above what was measured; low and high end bracket the measured number.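

In this assay compound 4 gives 17000 nM, and it is the only one of the four compounds shown with a measured number rather than a limit, so this position on the amide-type nitrogen now has one firm reading. Placing 4-hydroxy-3-methylphenyl here keeps the heavy-atom count of 4-methoxyphenyl and adds a hydrogen-bond donor, while the comparison with 3-(methylcarbamoyl)phenyl gives an at least 1.2-fold lower number from compound 3 to compound 4 (0.11 log units; that floor lies within the scatter), so a real difference between those two groups is neither shown nor ruled out. The steps from compound 1 and from compound 2 to compound 4 cannot be read, nor can those among the three earlier compounds, since each of those compounds is given only as a limit, which for compound 2 is: the limit of > 16000 nM in this assay, at which 1 of the 4 values shown sits.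

From the compounds shown here alone, it remains open whether the hydroxy or the methyl of 4-hydroxy-3-methylphenyl matters more on its own in this assay. Also open, going by these compounds, is how an amine or a carboxylic acid on this aromatic ring would read, and where the true numbers behind the three limits lie.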